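The source may report more compounds than this note shows. Statements on the series, on what has been measured and on what is new or still open speak of the compounds shown alone.

Working notes on the series. The shared core of compound 1 `ClCc1ccccc1Cn1cnc2c(Cl)ncnc21` carries a chloro group and a chloromethyl-bearing arm. In a functional assay on K562 cells (Homo sapiens) for cytotoxicity, read by sulforhodamine B assay, with a stated time of 48 h (on this read-out lower numbers stand for higher toxicity in this test and higher numbers for lower toxicity in this test), compound 1 reaches only the limit > 100000 nM. Compound 2 `ClCc1cccc(Cn2cnc3c(Cl)ncnc32)c1` is an isomer of compound 1. In this assay compound 2 gives 75900 nM. Compound 3 `ClCc1cccc(Cn2cnc3c(Cl)nc(Cl)nc32)c1` carries one further chloro on the core. In this assay compound 3 sits at the limit > 100000 nM. The step of an at least 1.3-fold higher number from compound 2 to compound 3 (0.11 log units; that floor lies within the scatter) is accordingly only a floor. Compound 3 thus stands at the same limit as compound 1 (the limit of > 100000 nM in this assay, at which 2 of the 3 values shown sit); only compound 2 yields a number, and that number lies close to the limit.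

Compound 4 `Nc1nc(Cl)c2ncn(Cc3cccc(CCl)c3)c2n1` differs from compound 3 by amino in place of chloro on an aromatic carbon. Going by the values given here, no measured step concerns a chloro-to-amino exchange; the single measured step, an at least 1.3-fold higher number from compound 2 to compound 3 (0.11 log units; that floor lies within the scatter), was itself within the scatter. No step beyond the scatter is therefore expected in this assay, in either direction. Compound 4 is expected to give about 100000 nM in this assay, with a range of 40000 nM to 300000 nM, most probably reported again as a limit. The step of a number no higher from compound 3 to compound 4 (the limit leaves the size open) thus expected is essentially none beyond the scatter.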

Compound 4, concentration lethal to 50% of the cells: > 100000 nM
Compound 4: no number, only a limit; the forecaster's own chance of this, stated with the estimate: 70%; the middle value lies on the limit itself.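

In this assay compound 4 gives > 100000 nM, which is a limit and not a number. At the position between two ring nitrogen atoms, amino in place of hydrogen gives an at least 1.3-fold higher number from compound 2 to compound 4 (0.11 log units; that floor lies within the scatter), so amino at this position produces no step beyond the scatter. The exchange of chloro for amino cannot be read, as both of its ends are limits, and the series now gathers at one value: the limit of > 100000 nM in this assay, at which 3 of the 4 values shown sit.

Going by these compounds, it remains open whether a methoxy or a dimethylamino group at this position would give a number clear of the limit. On these data alone, it also remains open whether a hydroxymethyl group in place of the chloromethyl group would shift the values in this assay.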